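Trifluoromethyl in Place of Methyl on the Pendant Phenyl

The source may report more compounds than this note shows. Statements on the series, on what has been measured and on what is new or still open speak of the compounds shown alone.

Three compounds share one core and differ only in where a methyl sits on the attached phenyl: compound 1 `CCCS(=O)(=O)Nc1ccc(F)c(C(=O)c2n[nH]c3ncc(-c4ccccc4C)cc23)c1F`, compound 2 `CCCS(=O)(=O)Nc1ccc(F)c(C(=O)c2n[nH]c3ncc(-c4cccc(C)c4)cc23)c1F` and compound 3 `CCCS(=O)(=O)Nc1ccc(F)c(C(=O)c2n[nH]c3ncc(-c4ccc(C)cc4)cc23)c1F`. In an assay for binding affinity to dual specificity mitogen-activated protein kinase kinase 4 (Homo sapiens), read by KINOMEscan, tested at 100 nM (on this read-out lower numbers stand for a stronger effect and higher numbers for a weaker effect at the one concentration tested), compound 1 gives 7%, compound 2 gives 15% and compound 3 gives 5.4%. Compound 3 holds the lowest of the three numbers, but its steps to the others are a number 1.6 percentage points lower from compound 1 to compound 3 (within the scatter) and a number 9.6 percentage points lower from compound 2 to compound 3 (within the scatter), and the remaining step is a number 8 percentage points higher from compound 1 to compound 2 (within the scatter), so all three stand within the scatter of one another and no order among them can be claimed.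

Compound 4 `CCCS(=O)(=O)Nc1ccc(F)c(C(=O)c2n[nH]c3ncc(-c4ccc(C(F)(F)F)cc4)cc23)c1F` changes compound 3 by trifluoromethyl in place of methyl on an aromatic carbon. Within the data shown here, no measured step exchanges a methyl for a trifluoromethyl; the steps that bear on the question only move the methyl around the ring, and each of them lies within the scatter. On that basis compound 4 is expected to show a step of a number 4.6 percentage points higher from compound 3 to compound 4 (within the scatter) in this assay, that is, nothing beyond the scatter, although the entering group has not been tested here and the range is set wide to allow for that. Compound 4 is therefore estimated at 10%, between 2% and 40%.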

Compound 4, a percentage reported as activity, at one concentration (the size of the read-out at that concentration, not a potency): 29%
Compound 4: the middle estimate sits 19 percentage points below what was measured, and the stated range covers the measured number.
By their numbers in this assay, from the lowest: compounds 3, 1 and 2 (each within the scatter of the next); then compound 4.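

In this assay, among these compounds, the first change to carry the number beyond the scatter is the one made on the aromatic carbon para to a large group, with a number 23.6 percentage points higher from compound 3 to compound 4 (beyond the scatter) when trifluoromethyl takes the place of methyl. Moving the methyl around the ring had given no step beyond the scatter, yet compound 4 stands apart from both other methyl compounds, with a number 14 percentage points higher from compound 2 to compound 4 (beyond the scatter) and a number 22 percentage points higher from compound 1 to compound 4 (beyond the scatter) as well, so the read-out at this concentration responds to which group is present on the phenyl and the effect is weaker with trifluoromethyl in this series. Nothing available gives a measured reason for this step.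

The compounds shown leave open how a chlorine, a methoxy group, a nitrile or an amine on the same carbon would read, and so whether the step follows from this one group or is shared by others. They also leave open whether trifluoromethyl would give a step of like size on the ring carbons that carry the methyl in compound 1 and compound 2.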